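From an Iodophenyl Amide to a Trifluoromethylphenyl Amide

The source may hold more compounds than are shown below. What is called first, only, known or untested is meant among the compounds shown, and "the series" means these compounds.

Three amides that share one core have been measured in a functional assay on MDA-MB-231 cells (Homo sapiens) for antiproliferative activity, read by MTT assay, with a stated time of 24 h; a lower number here means a stronger inhibitor, a higher number a weaker inhibitor. Compound 3 `COC(=O)c1scc(-c2ccc(NC(=O)c3cccc(I)c3)cc2)c1OC` gives 8240 nM. Compound 1 `COC(=O)c1scc(-c2ccc(NC(=O)c3ccc(F)c(Cl)n3)cc2)c1OC` gives 10300 nM, and a 1.3-fold lower number from compound 1 to compound 3 (0.10 log units; within the scatter) leaves these two level with each other. Compound 2 `COC(=O)c1scc(-c2ccc(NC(=O)c3ccc(C(F)(F)F)cc3Br)cc2)c1OC` gives 19600 nM, a higher number than compound 3 shows, by more than the usual scatter.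

Compound 4 `COC(=O)c1scc(-c2ccc(NC(=O)c3ccc(C(F)(F)F)cc3)cc2)c1OC` has not yet been measured. It carries 4-(trifluoromethyl)phenyl in place of 3-iodophenyl on a carbonyl carbon, and the amide-type nitrogen stays on that carbon: 4-(trifluoromethyl)phenyl in place of 3-iodophenyl on a carbonyl carbon.

Among the measured compounds shown here, only one measured step changes this same place, a 1.3-fold lower number from compound 1 to compound 3 (0.10 log units; within the scatter), and it stays within the scatter. That gives little reason to expect a large change in this assay here. Compound 2 also carries a trifluoromethyl group, together with a bromine, and its value of 19600 nM tilts the expectation slightly towards a higher number. For the measured compounds named here, no measured step separates the effect of those two groups, so this hint is weak. The expected change is small, a 1.5-fold higher number from compound 3 to compound 4 (0.16 log units; within the scatter), and no step beyond the scatter is expected. For compound 4 the estimated value is 12000 nM, with an expected range from 5500 nM to 25000 nM.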

Compound 4, half-maximal inhibitory concentration: 18300 nM
For compound 4 the middle estimate is 1.5-fold (0.18 log units) below the measured one; measured number inside the range.
By their numbers in this assay, from the lowest: compounds 3, 1, 4 and 2 (each within the scatter of the next, the first and the last beyond it).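

Among the compounds shown here, the change from 3-iodophenyl to 4-(trifluoromethyl)phenyl on the carbonyl carbon gives a 2.2-fold higher number from compound 3 to compound 4 (0.35 log units; beyond the scatter) in this assay and is the first change here to pass the scatter, so this place does respond to the group it carries, though only modestly. The same entering group set against 6-chloro-5-fluoropyridin-2-yl gives a 1.8-fold higher number from compound 1 to compound 4 (0.25 log units; within the scatter) and stays within the scatter, which means only the 3-iodophenyl and 4-(trifluoromethyl)phenyl amides can be told apart so far. Hydrogen in place of bromo on an aromatic carbon gives a 1.1-fold lower number from compound 2 to compound 4 (0.03 log units; within the scatter) and also stays within the scatter, so the number seen for compound 2 does not depend on its bromine, and the bromine that clouded the earlier hint can be set aside.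

All the amides shown carry halogens or trifluoromethyl on their rings, so it remains open how a phenyl ring bearing an amine or a carboxylic acid would behave at this place, and whether any group here can bring the number well below that of compound 3. Nothing available explains the difference between these groups.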